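The source may report more compounds than this note shows. Statements on the series, on what has been measured and on what is new or still open speak of the compounds shown alone.

Compound 1 `O=S(=O)(Cc1nc(-c2cccs2)c2sccc2n1)c1cccc(Cl)c1` in an ADME assay on cells (Homo sapiens) for cytotoxicity, read by resazurin assay, with a stated time of 5 days; a lower number here means that less compound is tolerated, a higher number that more compound is tolerated: > 50000 nM, a limit of the assay rather than a number.
Compound 2 `COc1ccc(-c2nc(COc3cccc(Cl)c3)nc3ccsc23)cn1` in this assay: > 50000 nM, also a limit.
Compound 3 `COc1ccc(Nc2nc(CS(=O)(=O)c3cccc(Cl)c3)nc3ccsc23)cc1` in this assay: 60000 nM.

On these numbers compound 2 stands only at a limit, and one further value is a limit too; compound 3 alone gives a number. Compound 4 `COc1ccc(-c2nc(CSCc3cccc(Cl)c3)nc3ccsc23)cn1` differs from compound 2 by (3-chlorobenzyl)sulfanyl in place of 3-chlorophenoxy on a saturated chain carbon bound to an aromatic carbon. Within the data shown here, no measured step touches this place: the only measured step, a step that the limit leaves unreadable from compound 1 to compound 3, sits elsewhere, and its size cannot be read because of the limit. Given (the limit of > 50000 nM in this assay, at which 2 of the 3 values shown sit), no shift beyond the scatter is expected. Compound 4 is estimated at 60000 nM, between 30000 nM and 120000 nM. The expected step that the limit leaves unreadable from compound 2 to compound 4 is therefore none beyond the scatter.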

Compound 4, half-maximal cytotoxic concentration: > 50000 nM
Compound 4: only a limit was reported; the forecaster's own chance of this, stated with the estimate: 70%; the middle value lies beyond the limit too.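

Compound 2 and compound 4 both end at a limit rather than a number, so the step between them cannot be read: the limit of > 50000 nM in this assay, at which 3 of the 4 values shown sit. As far as these compounds go, whether (3-chlorobenzyl)sulfanyl in place of 3-chlorophenoxy changes how much compound is tolerated remains open.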